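Swapping the Amide Aryl Group: Compound 1 to Compound 4

The source may hold more compounds than are shown below. What is called first, only, known or untested is meant among the compounds shown, and "the series" means these compounds.

Compound 1 `COc1cccc(NC(=O)CSc2nc(Nc3ccccc3)c3ccccc3n2)c1` gives 11600 nM in a functional assay on PC-3 cells (Homo sapiens) for inhibition, read by MTT assay, with a stated time of 72 h; a higher number here means a weaker inhibitor, a lower number a stronger inhibitor.
Compound 2 `O=C(CSc1nc(Nc2ccccc2)c2ccccc2n1)Nc1ccc(Br)cc1` gives 8450 nM in this assay.
Compound 3 `O=C(CSc1nc(Nc2ccccc2)c2ccccc2n1)Nc1ccc(Cl)cc1Cl` gives 9110 nM in this assay.

All three share one core and differ only in the aryl group attached to the amide-type nitrogen. Among the three numbers compound 1 has the highest, but the others sit close: the nearest is compound 3, reached by a 1.3-fold lower number from compound 1 to compound 3 (0.10 log units; within the scatter), and the furthest is compound 2, reached by a 1.4-fold lower number from compound 1 to compound 2 (0.14 log units; within the scatter). Neither gap is larger than repeated measurements of this kind would show by themselves, so the three compounds cannot be told apart on these data.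

Compound 4 `O=C(CSc1nc(Nc2ccccc2)c2ccccc2n1)Nc1ccc(F)c(Cl)c1` is not yet measured. Relative to compound 1 the change is 3-chloro-4-fluorophenyl in place of 3-methoxyphenyl on an amide-type nitrogen.

The two steps that bear on this are those from compound 1 to compound 2 and from compound 1 to compound 3, each replacing 3-methoxyphenyl with a phenyl group carrying one or two halogen atoms, and each staying within the scatter; the step of a 1.1-fold higher number from compound 2 to compound 3 (0.03 log units; within the scatter) shows the same. On that basis compound 4 is expected to show no change beyond the scatter in this assay, that is a 1.2-fold lower number from compound 1 to compound 4 (0.09 log units; within the scatter). The estimated value for compound 4 is 9500 nM, within a range from 5000 nM to 18000 nM.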

Compound 4, half-maximal inhibitory concentration: 15500 nM
Beside the measured number, compound 4's estimate is 1.6-fold (0.21 log units) below it; measured number inside the range.
By their numbers in this assay, from the lowest: compounds 2, 3, 1 and 4 (each within the scatter of the next).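

Going by these compounds alone, compound 4 brings fluorine to the aryl group on the amide-type nitrogen for the first time, and in this assay this fourth group still cannot be told apart from the other three (a 1.3-fold higher number from compound 1 to compound 4 (0.13 log units; within the scatter); a 1.7-fold higher number from compound 3 to compound 4 (0.23 log units; within the scatter); a 1.8-fold higher number from compound 2 to compound 4 (0.26 log units; within the scatter)). The two groups in the first of these steps, 3-methoxyphenyl and 3-chloro-4-fluorophenyl, each count 8 heavy atoms yet carry different substituents, and the change between them stays within the scatter, as do the changes from the 2,4-dichlorophenyl and 4-bromophenyl groups, even though these last two steps are the largest seen so far at this position. No measurement shown here offers an explanation for any of these small differences.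

From the compounds shown here alone, all four compounds carry a substituted phenyl ring at this position, so it remains open whether an amine or a carboxylic acid on that ring would move the number beyond the scatter. Also open, going by these compounds, is what a longer chain between the amide-type nitrogen and the ring, or a saturated cyclohexyl group in place of the phenyl ring, would do in this assay.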